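Methyl on the pyrrole nitrogen: a step with no anchor

The source may report more compounds than this note shows. Statements on the series, on what has been measured and on what is new or still open speak of the compounds shown alone.

Measured compounds:
- compound 1 `O=C(Nc1ccc(Oc2ccnc3[nH]ccc23)cc1)c1cc2cccnc2n(-c2ccc(F)c(Cl)c2)c1=O`: "not determined" (no result reported)
- compound 2 `O=C(Nc1ccc(Oc2ccnc3[nH]ccc23)cc1)c1cc2cccnc2n(-c2ccc(Br)cc2F)c1=O`: "not determined" (no result reported)
- compound 3 `O=C(Nc1ccc(Oc2ccnc3[nH]ccc23)cc1)c1cc2cccnc2n(-c2ccc(C(F)(F)F)cc2Cl)c1=O`: 1950 nM

All three share one core, a fused bicyclic amide linked through an ether to a five-membered aromatic ring system; they differ only in the halogenated phenyl ring on the ring nitrogen of the core. In a functional assay on NCI-H460 cells (Homo sapiens) for antiproliferative activity, read by MTT assay, with a stated time of 72 h (on this read-out lower numbers stand for stronger inhibition and higher numbers for weaker inhibition), compound 1 gives "not determined" (no result reported), so no number is known for it, and compound 2 likewise gives "not determined" (no result reported). Among the measured compounds shown here, the only number comes from compound 3, which in this assay gives 1950 nM. For the measured compounds named here, compound 1 therefore stands without a value of its own, and no step between measured compounds can be drawn.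

Compound 4 `Cn1ccc2c(Oc3ccc(NC(=O)c4cc5cccnc5n(-c5ccc(F)c(Cl)c5)c4=O)cc3)ccnc21` is the unmeasured analogue of compound 1. The change is methyl in place of hydrogen on an aromatic nitrogen. Going by the values given here, no measured pair shows what this exchange does, so any expectation rests on the single number for compound 3 as a rough anchor for the series. The step from compound 1 to compound 4 is expected to move in the direction of weaker inhibition, beyond the scatter, though with wide uncertainty. For compound 4 in this assay the estimate is 6000 nM, with a range from 1000 nM to 30000 nM.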

Compound 4, half-maximal inhibitory concentration: 1210 nM
Estimate against measurement, compound 4: 5.0-fold (0.70 log units) above; measured number inside the range.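

In this assay, among the compounds shown here, compound 4 gives 1210 nM while compound 1 gives "not determined" (no result reported) and has no number, so no step between compound 1 and compound 4 can be read. No evidence shown bears on this result. As far as these compounds go, what methyl in place of hydrogen on the aromatic nitrogen does to inhibition stays open.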